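The source may hold more compounds than are shown below. What is called first, only, known or untested is meant among the compounds shown, and "the series" means these compounds.

In an ADME assay on Raji cells (Homo sapiens) for cytotoxicity, read by CellTiter-Glo and resazurin assay, with a stated time of 72 h (a higher number here means that more compound is needed for the effect, a lower number that less compound is needed), compound 1, `CC(C)N(Cc1cccc(OCCCCCC(=O)O)c1)C(=O)c1ccc(-c2ccc3c(c2)OCCO3)cc1`, gives only a limit of > 21900 nM. Compound 3, `CCOC(=O)CCCCCOc1cccc(CN(C(=O)c2ccc(-c3ccc4c(c3)OCCO4)cc2)C(C)C)c1`, differs from compound 1 by ethyl in place of hydrogen on an oxygen next to a carbonyl group. In this assay compound 3 also gives only a limit, > 24400 nM. The step that the two limits leave unreadable from compound 1 to compound 3 therefore cannot be read in size. Compound 2, `CC(C)N(Cc1cccc(OCCCCCC(=O)O)c1)C(=O)c1ccc(-c2cc3ccccc3n2S(=O)(=O)c2ccccc2)cc1`, carries the same side chain on a different core; how the two cores differ is not broken down here. In this assay compound 2 gives only a limit of > 26000 nM. Compound 4, `CCOC(=O)CCCCCOc1cccc(CN(C(=O)c2ccc(-c3cc4ccccc4n3S(=O)(=O)c3ccccc3)cc2)C(C)C)c1`, differs from compound 2 by ethyl in place of hydrogen on an oxygen next to a carbonyl group, the same change as from compound 1 to compound 3. Because (the limit of > 21900 nM in this assay, at which 1 of the 3 values shown sits), the limit of > 24400 nM in this assay, at which 1 of the 3 values shown sits, and the limit of > 26000 nM in this assay, at which 1 of the 3 values shown sits, are all limits rather than numbers, the step from compound 2 to compound 4 is expected to be a step that the limit leaves unreadable from compound 2 to compound 4. Compound 4 is expected to give 30000 nM in this assay, most likely again only as a limit.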

Compound 4, half-maximal effective concentration: > 26000 nM
Compound 4: only a limit was reported (the forecaster's own chance of this, stated with the estimate: 85%); the middle value lies beyond the limit too.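

Compound 2 and compound 4 both give only limits in this assay, so the step between them cannot be read. The compounds shown leave open whether ethyl in place of hydrogen changes the concentration needed for the effect.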